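Adding a hydroxy group to the phenyl of compound 2

The source may hold more compounds than are shown below. What is called first, only, known or untested is meant among the compounds shown, and "the series" means these compounds.

Among the compounds with values here, in a functional assay on A549 cells (Homo sapiens) for inhibition, read by MTT assay, with a stated time of 48 h (a lower number here means a stronger inhibitor, a higher number a weaker inhibitor), compound 2 (`COc1cc(-c2nccn3cc(-c4ccccc4)nc23)cc(OC)c1OC`) gives 378 nM as the higher of the two numbers so far, and compound 1 (`COc1cc(-c2nccn3cc(-c4ccc5[nH]ccc5c4)nc23)cc(OC)c1OC`) gives 154 nM as its only neighbour. Compound 3 (`COc1cc(-c2nccn3cc(-c4ccc(O)cc4)nc23)cc(OC)c1OC`) keeps the shared core and carries hydroxy in place of hydrogen on an aromatic carbon, so phenyl becomes 4-hydroxyphenyl. Within the data shown here, the one measured step that bears on this change involves the same phenyl group: a 2.5-fold higher number from compound 1 to compound 2 (0.39 log units; beyond the scatter) when phenyl stands in place of 1H-indol-5-yl. Among the measured compounds shown here, that step is modest, and no measured compound carries the hydroxy group, so only a small shift toward a lower number is expected (a 1.6-fold lower number from compound 2 to compound 3 (0.20 log units; within the scatter)). In this assay compound 3 is estimated at 240 nM (expected range 90 nM to 650 nM).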

Compound 3, half-maximal inhibitory concentration: > 10000 nM
Compound 3: only a limit was reported (the forecaster's own chance of this, stated with the estimate: 3%); middle value at least 41-fold (1.61 log units) away from the limit.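

In this assay the reading for compound 3 is a limit of the assay and not a number: the limit of > 10000 nM in this assay, at which 1 of the 3 values shown sits. Hydroxy on the aromatic carbon para to a large group gives an at least 26-fold higher number from compound 2 to compound 3 (1.42 log units; beyond the scatter), and 4-hydroxyphenyl in place of 1H-indol-5-yl gives an at least 64-fold higher number from compound 1 to compound 3 (1.81 log units; beyond the scatter). This position had shown only a modest step between two aromatic groups, but it is far from indifferent to this small change, and both new steps are large, with their full size hidden by the limit.

The compounds shown leave open whether this sharp rise belongs to the hydroxy group itself or would follow any group at this place. A methoxy group, a fluorine atom or an amine on the same carbon would separate these two readings.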